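This account rests on a few compounds, and the source may have more. Where it says the series, first, only, none or still open, it means among the compounds named here.

Measured so far in a functional assay on NCI-H460 cells (Homo sapiens) for cytotoxicity, read by MTT assay, with a stated time of 72 h; on this read-out higher numbers stand for weaker inhibition and lower numbers for stronger inhibition: compound 1 `CN(C)CCn1cnnc1-c1cc(Oc2ccc(NC(=O)N/N=C/c3cccc(Br)c3)cc2F)ccn1` gives 520 nM; compound 2 `CN(C)CCn1cnnc1-c1cc(Oc2ccc(NC(=O)N/N=C/c3ccc(Cl)cc3)cc2F)ccn1` gives 320 nM; compound 3 `CN(C)CCn1cnnc1-c1cc(Oc2ccc(NC(=O)N/N=C/c3ccc(O)c(Br)c3)cc2F)ccn1` gives 430 nM.

Compound 3 holds the second highest of the three numbers, with both neighbours within the scatter. Compound 4 `CN(C)CCn1cnnc1-c1cc(Oc2ccc(NC(=O)N/N=C/c3ccc(F)cc3F)cc2F)ccn1` differs from compound 3 by 2,4-difluorophenyl in place of 3-bromo-4-hydroxyphenyl on a carbon with a double bond to nitrogen. Two measured steps likewise exchange the aryl group on the carbon with a double bond to nitrogen: a 1.6-fold lower number from compound 1 to compound 2 (0.21 log units; within the scatter) and a 1.3-fold higher number from compound 2 to compound 3 (0.13 log units; within the scatter). A third, a 1.2-fold lower number from compound 1 to compound 3 (0.08 log units; within the scatter), adds hydroxy alone. Every one of these lies within the scatter, so no step beyond the scatter is expected here. The expected step is a 1.1-fold lower number from compound 3 to compound 4 (0.03 log units; within the scatter). For compound 4 in this assay the estimate is 400 nM, with a range of 200 nM to 800 nM.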

Compound 4, half-maximal inhibitory concentration: 1930 nM
Compound 4: the middle estimate sits 4.8-fold (0.68 log units) below what was measured; the measured number lies above the stated range.
By their numbers in this assay, from the lowest: compounds 2, 3 and 1 (each within the scatter of the next); then compound 4.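

At this position, on a carbon with a double bond to nitrogen, the aryl exchanges among compounds 1, 2 and 3 stayed within the scatter, so the position looked indifferent to the aryl group. In this assay, going by these compounds alone, 2,4-difluorophenyl is the first group to break that picture, with a 4.5-fold higher number from compound 3 to compound 4 (0.65 log units; beyond the scatter) and a 6.0-fold higher number from compound 2 to compound 4 (0.78 log units; beyond the scatter) as well as a 3.7-fold higher number from compound 1 to compound 4 (0.57 log units; beyond the scatter) and all three beyond the scatter, which makes compound 4 the weakest of the four. Nothing measured here accounts for this loss.

Going by these compounds, whether the loss follows both fluorines together or only one stays open. On these data alone, how a phenyl ring carrying a single fluorine, a methoxy group or an amine would behave here also remains unknown.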